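The compounds below may be only part of what the source reports. "The series", "measured", "known", "first", "only" and "open" are said of these compounds alone.

Measured compounds:
Compound 1 `O=C(CCc1cccc2c1B(O)OC2)NC1CCCCC1` — in a functional assay on HCT-116 cells (Homo sapiens) for antiproliferative activity, read by MTT assay, with a stated time of 72 h (a lower number here means a stronger inhibitor, a higher number a weaker inhibitor), compound 1 gives > 100000 nM, a limit of the assay.
Compound 2 `O=C(CCc1cccc2c1B(O)OC2)NCc1ccccc1` — in this assay compound 2 gives > 100000 nM, also a limit.
Compound 3 `O=C(CCc1cccc2c1B(O)OC2)Nc1ccc(Br)cc1` — in this assay compound 3 gives 46000 nM.

Going by the values given here, compound 3 thus holds the only number in the set; the two other values sit at the limit of > 100000 nM in this assay, at which 2 of the 3 values shown sit. The step of an at least 2.1-fold lower number from compound 1 to compound 3 (0.33 log units; beyond the scatter) and the step of an at least 2.1-fold lower number from compound 2 to compound 3 (0.33 log units; beyond the scatter) point the same way, the aryl amide giving a lower number than the cyclohexyl or benzyl amide, though neither step has a readable size. Compound 4 `CC(C)(C)OC(=O)Nc1ccc(NC(=O)CCc2cccc3c2B(O)OC3)cc1` keeps the aryl amide of compound 3 and differs by (tert-butoxycarbonyl)amino in place of bromo on an aromatic carbon. Among the compounds with values here, no measured step touches this position, so no direction can be read from the data. Compound 4 is expected near compound 3, the step of a 1.5-fold lower number from compound 3 to compound 4 (0.19 log units; within the scatter) being estimated to stay within the scatter. The estimate for compound 4 in this assay is 30000 nM, with a range of 8000 nM to 100000 nM.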

Compound 4, half-maximal inhibitory concentration: 24000 nM
Compound 4: the middle estimate sits 1.3-fold (0.10 log units) above what was measured; low and high end bracket the measured number.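

In this assay, (tert-butoxycarbonyl)amino in place of bromo on this aromatic carbon gives a 1.9-fold lower number from compound 3 to compound 4 (0.28 log units; within the scatter). A group of 8 heavy atoms thus replaces a single bromine atom here with no change beyond the scatter, so this aromatic carbon accepts a far larger substituent while the aryl amide stays in place. No measured property in the data bears on this step.

On these data alone, whether a free amine or a carboxylic acid on this aromatic carbon would shift the number beyond the scatter remains open. Also open, as far as these compounds go, is the effect of a longer chain on the shared core.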